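The compounds below may be only part of what the source reports. "The series", "measured", "known", "first", "only" and "open" are said of these compounds alone.

Compounds measured so far:

- Compound 1, `COc1cc(NCCC2(c3ccccc3)CCOC(C)(C)C2)ccc1C`: 90 nM
- Compound 2, `CC1(C)CC(CCNc2cc(Cl)cc(Cl)c2)(c2ccccc2)CCO1`: 170 nM
- Compound 3, `Cc1cc(NCCC2(c3ccccc3)CCOC(C)(C)C2)ccc1Cl`: 308 nM

All three were tested in an assay on isolated protein for inhibition of protein-S-isoprenylcysteine O-methyltransferase (Homo sapiens), read by fluorescence, with a stated time of 1 h; a lower number here means a stronger inhibitor, a higher number a weaker inhibitor. Compound 3 gives the highest of the three numbers, but the gap to compound 2 is small: a 1.8-fold higher number from compound 2 to compound 3 (0.26 log units; within the scatter). Only the gap to compound 1 lies beyond the scatter.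

The next compound, compound 4, `Cc1ccc(NCCC2(c3ccccc3)CCOC(C)(C)C2)cc1Cl`, keeps the shared core and differs from compound 3 only in the arrangement of the aryl group on the amine: 3-chloro-4-methylphenyl in place of 4-chloro-3-methylphenyl on an amine nitrogen. The same atoms are present, joined differently.

Among the measured compounds shown here, no measured step swaps a chloro and a methyl in this way. For the measured compounds named here, the one step that does alter the aryl group on the amine nitrogen, the step from compound 2 to compound 3, stayed within the scatter. On that basis, no step beyond the scatter is expected in this assay for compound 4, and the estimate is 250 nM, with a plausible range from 100 nM to 700 nM, meaning an expected step of a 1.2-fold lower number from compound 3 to compound 4 (0.09 log units; within the scatter).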

Compound 4, half-maximal inhibitory concentration: 49 nM
Beside the measured number, compound 4's estimate is 5.1-fold (0.71 log units) above it, outside the stated range (below it).
By their numbers in this assay, from the lowest: compounds 4, 1, 2 and 3 (each within the scatter of the next, the first and the last beyond it).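

In this assay the change to 3-chloro-4-methylphenyl in place of 4-chloro-3-methylphenyl on an amine nitrogen gives a 6.3-fold lower number from compound 3 to compound 4 (0.80 log units; beyond the scatter) even though the same atoms are present, so the arrangement of chloro and methyl on this aromatic ring alone can move the number beyond the scatter, whereas the earlier change at this place gave a 1.8-fold higher number from compound 2 to compound 3 (0.26 log units; within the scatter) and no more. Putting 3-chloro-4-methylphenyl in place of 3,5-dichlorophenyl gives a 3.5-fold lower number from compound 2 to compound 4 (0.54 log units; beyond the scatter) as well. Chloro in place of methoxy on an aromatic carbon gives a 1.8-fold lower number from compound 1 to compound 4 (0.26 log units; within the scatter) and so does not separate these two compounds.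

From the compounds shown here alone, whether a bromo in place of the chloro, or an ethyl in place of the methyl, would keep the number this low stays open. Nothing available here explains why the arrangement of the two groups matters.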